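Hydrazone series: dichlorophenyl replacing dimethylphenyl at the amine nitrogen

A few compounds are considered here, and "the series" means these few. Any claim that something is new, unique, unknown or untested is made for them only; others in the source may bear on it.

Compound 2 `Cc1ccc(NN=C2CCC(C)n3c2ncc(C(=O)O)c3=O)cc1C` carries a 3,4-dimethylphenyl group on the amine nitrogen. In a functional assay on the whole organism with Rattus norvegicus as the target (on this read-out higher numbers stand for an effect only at larger amounts of compound and lower numbers for an effect already at smaller amounts), compound 2 gives > 100 umol/kg, which is a limit of the assay rather than a number. Compound 3 `Cc1cc(C)c(NN=C2CCC(C)n3c2ncc(C(=O)O)c3=O)cc1C` differs by methyl in place of hydrogen on an aromatic carbon, and in this assay compound 3 gives 320 umol/kg. The step that the limit leaves unreadable from compound 2 to compound 3 cannot be sized, because the limit of > 100 umol/kg in this assay, at which 2 of the 3 values shown sit, is where the value of compound 2 sits. Compound 1 `CC1CCC(=NNc2ccccc2)c2ncc(C(=O)NO)c(=O)n21` gives > 100 umol/kg in this assay, again a limit. Only compound 3 has a measured number in this set.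

Compound 4 `CC1CCC(=NNc2ccc(Cl)c(Cl)c2)c2ncc(C(=O)O)c(=O)n21` is the next candidate, differing from compound 2 by 3,4-dichlorophenyl in place of 3,4-dimethylphenyl on an amine nitrogen. No measured step in this series exchanges a dimethylphenyl for a dichlorophenyl, so nothing shown speaks directly to the size or direction of this change. Going by the values given here, the only readable value, that of compound 3, sits well into the weak range, and the two limits do not sharpen the picture.

The step from compound 2 to compound 4 is therefore expected as a step that the limit leaves unreadable from compound 2 to compound 4, with no direction favoured beyond the scatter. For compound 4 the estimated value in this assay is 200 umol/kg, in the range 60 umol/kg to 800 umol/kg.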

Compound 4, dose for 50% inhibition: > 100 umol/kg
Compound 4: only a limit was reported; the forecaster's own chance of this, stated with the estimate: 50%; the middle value does not contradict the limit.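

In this assay compound 4 gives > 100 umol/kg, a limit of the assay and not a number. No step can be read from compound 2 to compound 4, because both sit at the same limit: the limit of > 100 umol/kg in this assay, at which 3 of the 4 values shown sit.

From the compounds shown here alone, whether 3,4-dichlorophenyl in place of 3,4-dimethylphenyl on an amine nitrogen shifts the dose in either direction stays open.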